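Thiophen-3-yl gives way to 4-methoxyphenyl

The source may report more compounds than this note shows. Statements on the series, on what has been measured and on what is new or still open speak of the compounds shown alone.

Measured so far in a functional assay on L1210 cells (Mus musculus) for antiproliferative activity (on this read-out higher numbers stand for weaker inhibition and lower numbers for stronger inhibition), for three compounds:
Compound 1 (`COc1cc(C(=O)c2sc(-c3ccc(-c4ccccc4)cc3)cc2N)cc(OC)c1OC`) gives > 10000 nM as a limit
Compound 2 (`COc1ccc(-c2cc(N)c(C(=O)c3cc(OC)c(OC)c(OC)c3)s2)cc1OC`) gives 40 nM as a number
Compound 3 (`COc1cc(C(=O)c2sc(-c3ccsc3)cc2N)cc(OC)c1OC`) gives 12 nM as a number

Only two of these results are numbers, and compound 3 holds the lower of them, which makes it the stronger inhibitor of that pair. Compound 1 stands at a limit of the assay (the limit of > 10000 nM in this assay, at which 1 of the 3 values shown sits) and gives no number.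

The next compound, compound 4 (`COc1ccc(-c2cc(N)c(C(=O)c3cc(OC)c(OC)c(OC)c3)s2)cc1`), carries 4-methoxyphenyl in place of thiophen-3-yl on an aromatic carbon. Among the compounds with values here, one measured step bears on this exchange, namely a 3.3-fold lower number from compound 2 to compound 3 (0.52 log units; beyond the scatter), where thiophen-3-yl replaced 3,4-dimethoxyphenyl at that same place. That step is modest but beyond the scatter. Read in reverse, it points to a modest move toward a higher number when a methoxy-bearing phenyl ring returns in place of thiophen-3-yl. With a single step as the guide, the expectation stays loose.

The expected change is a 2.1-fold higher number from compound 3 to compound 4 (0.32 log units; beyond the scatter) in this assay as a modest weakening. For compound 4 the estimated value is 25 nM with an expected range from 6 nM to 120 nM in this read-out.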

Compound 4, half-maximal inhibitory concentration: 45 nM
For compound 4 the middle estimate is 1.8-fold (0.26 log units) below the measured one, within the range that was stated.
By their numbers in this assay, from the lowest: compound 3; then compounds 2 and 4 (each within the scatter of the next). At a limit, above all of these: compound 1.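

Moving from thiophen-3-yl to 4-methoxyphenyl on this aromatic carbon next to the ring sulfur gives a 3.8-fold higher number from compound 3 to compound 4 (0.57 log units; beyond the scatter) in this assay, so compound 3 now stands beyond the scatter from both compounds with a methoxy-bearing phenyl ring, not from compound 2 alone. The second methoxy on that phenyl ring makes no difference that can be read, since hydrogen in place of methoxy gives a 1.1-fold higher number from compound 2 to compound 4 (0.05 log units; within the scatter), and compound 2 and compound 4 cannot be told apart in this assay. Methoxy in place of phenyl on an aromatic carbon gives an at least 220-fold lower number from compound 1 to compound 4 (2.34 log units; beyond the scatter), a large step that starts from a limit and not from a number: the limit of > 10000 nM in this assay, at which 1 of the 4 values shown sits.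

The compounds shown leave open whether the low number of compound 3 belongs to thiophen-3-yl in particular or would also hold for another ring at this place, such as furan-3-yl, pyridin-3-yl or an unsubstituted phenyl. On these data alone, whether another group in the place of that methoxy, such as ethoxy, chloro or dimethylamino, would read close to compound 4 or close to the limit of compound 1 also stays open.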